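Pyrazoline series: para substituent swap on the aryl ring

The compounds below may be only part of what the source reports. "The series", "measured", "known", "first", "only" and "open" are said of these compounds alone.

Measured so far in a functional assay on PC-3 cells (Homo sapiens) for cytotoxicity, read by sulforhodamine B assay, with a stated time of 48 h; on this read-out higher numbers stand for weaker inhibition and lower numbers for stronger inhibition:
- compound 1, `CC(=O)N1N=C(c2ccco2)CC1c1ccc([N+](=O)[O-])cc1`: 21300 nM
- compound 2, `CC(=O)N1N=C(c2ccco2)CC1c1ccc(Cl)cc1`: 39000 nM

For the measured compounds named here, compound 2 carries the highest of the two numbers, but its only neighbour is compound 1, and the step of a 1.8-fold higher number from compound 1 to compound 2 (0.26 log units; within the scatter) stays within the scatter, so the two compounds cannot be ordered against each other.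

Compound 3, `COc1ccc(C2CC(c3ccco3)=NN2C(C)=O)cc1`, is the next member: methoxy in place of chloro on an aromatic carbon. Going by the values given here, the one measured step that bears on a change at this position is a 1.8-fold higher number from compound 1 to compound 2 (0.26 log units; within the scatter), which did not move the number beyond the scatter. Among the compounds with values here, no measured step shows methoxy at this place, so the expectation rests on that single comparison. On this basis no step beyond the scatter is expected in this assay, a 1.1-fold lower number from compound 2 to compound 3 (0.05 log units; within the scatter). Compound 3 is therefore estimated at 35000 nM, with a range from 15000 nM to 80000 nM.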

Compound 3, half-maximal inhibitory concentration: 15500 nM
Beside the measured number, compound 3's estimate is 2.3-fold (0.35 log units) above it; low and high end bracket the measured number.
By their numbers in this assay, from the lowest: compounds 3, 1 and 2 (each within the scatter of the next, the first and the last beyond it).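

In this assay this position now gives its first step beyond the scatter: a 2.5-fold lower number from compound 2 to compound 3 (0.40 log units; beyond the scatter) is modest, and it comes with methoxy in place of chloro on an aromatic carbon. Methoxy in place of nitro gives only a 1.4-fold lower number from compound 1 to compound 3 (0.14 log units; within the scatter) and stays within the scatter, so the position's response rests on the single pair of compound 2 and compound 3, while compound 1 cannot be separated from either. No measurement on hand accounts for the difference between compound 2 and compound 3.

The three compounds cover only nitro, chloro and methoxy at this one place on the shared core. As far as these compounds go, whether an amine, a hydroxyl or a longer alkoxy chain such as ethoxy would carry the number further from that of compound 2 remains open.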